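Cytotoxicity notes on compounds 1 to 3

A few compounds are considered here, and "the series" means these few. Any claim that something is new, unique, unknown or untested is made for them only; others in the source may bear on it.

Measured so far:
compound 1 `Cc1ccc(-c2ccc3[nH]c(=O)nc(-c4ccccc4)c3c2)cn1`: > 50000 nM
compound 2 `O=c1nc(-c2ccccc2)c2cc(-c3cnc4ccccc4c3)ccc2[nH]1`: > 16000 nM

Both readings in an ADME assay on L6 cells (Rattus norvegicus) for cytotoxicity, read by fluorescence and resazurin assay, with a stated time of 72 h (on this read-out higher numbers stand for an effect only at larger amounts of compound and lower numbers for an effect already at smaller amounts), are limits of the assay and not numbers. Compound 1 stands at the upper limit, (the limit of > 50000 nM in this assay, at which 1 of the 2 values shown sits). Compound 2 sits at a different limit, (the limit of > 16000 nM in this assay, at which 1 of the 2 values shown sits). Going by the values given here, neither gives a point on the scale, so compound 1 cannot be placed above or below compound 2; both show no effect within the range tested, and no step between measured compounds is available.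

Compound 3 `O=c1nc(-c2ccccc2)c2cc(-c3cc[nH]n3)ccc2[nH]1` is not yet measured. It differs from compound 1 by 1H-pyrazol-3-yl in place of 6-methylpyridin-3-yl on an aromatic carbon. Both measured compounds carry a six-membered aromatic group at this position and both stay at a limit; the shared core is otherwise unchanged.

Among the compounds with values here, with no measured step to guide the size, the expectation for this change in this assay is no step beyond the scatter, and compound 3 is expected to remain at or near the limit. The estimate for compound 3 is 50000 nM, range 20000 nM to 120000 nM, which means an expected step of a number no higher from compound 1 to compound 3 (the limit leaves the size open).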

Compound 3, half-maximal effective concentration: > 50000 nM
Compound 3: a limit, no number; the forecaster's own chance of this, stated with the estimate: 80%; the middle value sits exactly at the limit.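

In this assay compound 3 gives > 50000 nM, a limit and not a number. Compound 1 stands at a limit as well, so no step can be read between compound 1 and compound 3. The compounds shown leave open how 1H-pyrazol-3-yl and 6-methylpyridin-3-yl compare, and what concentration of either compound would produce an effect.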